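This account rests on a few compounds, and the source may have more. Where it says the series, first, only, none or still open, it means among the compounds named here.

Measured in an ADME assay on cells (Peritoneal macrophage cell, Mus musculus) for cytotoxicity; a lower number here means a stronger inhibitor, a higher number a weaker inhibitor:
- compound 1 `O=C(Cn1cnc([N+](=O)[O-])n1)Nc1ccc(Oc2ccccc2)cc1`: 89000 nM
- compound 2 `O=C(Cn1ccnc1[N+](=O)[O-])Nc1ccc(Oc2ccccc2)cc1`: > 89000 nM (a limit, not a number)

Compound 2 stands only at a limit, > 89000 nM. Compound 3 `O=C(Cn1ccnc1[N+](=O)[O-])Nc1ccc(Oc2ccc(F)cc2)cc1` differs from compound 2 by fluoro in place of hydrogen on an aromatic carbon, para to a large group. Among the compounds with values here, the only measured step, a number no lower from compound 1 to compound 2 (the limit leaves the size open), changes a different group and its size stays open, so it bears on this change only weakly. No shift beyond the scatter is expected in this assay, and the estimated at least 1.1-fold lower number from compound 2 to compound 3 (0.04 log units; that floor lies within the scatter) has no firm direction. Another limit would fit this expectation. For compound 3 the estimated value is 80000 nM, with an expected range of 35000 nM to 150000 nM.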

Compound 3, half-maximal inhibitory concentration: > 84000 nM
Compound 3: only a limit was reported (the forecaster's own chance of this, stated with the estimate: 65%); middle value at least 1.0-fold (0.02 log units) from the limit.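

Compound 2 and compound 3 both stand only at limits in this assay, so no step can be read from fluoro in place of hydrogen. The compounds shown leave open whether this change shifts the half-maximal inhibitory concentration at all.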